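Swapping the Amide Substituent of a Weakly Cytotoxic Compound

A few compounds are considered here, and "the series" means these few. Any claim that something is new, unique, unknown or untested is made for them only; others in the source may bear on it.

Measured compounds:
- compound 1, `CCOC(=O)C1(C(=O)Nc2ccccc2)CC1c1cc(OC)c(OC)c(OC)c1`: 31500 nM; 48600 nM (2 entries)
- compound 2, `CCOC(=O)[C@]1(C(=O)Nc2ccccc2)C[C@H]1c1cc(OC)c(OC)c(OC)c1`: 37300 nM
- compound 3, `COc1cc([C@H]2C[C@@]2(CO)C(=O)Nc2ccccc2)cc(OC)c1OC`: > 100000 nM

All three compounds were tested in a functional assay on A549 cells (Homo sapiens) for cytotoxicity, read by MTT assay, with a stated time of 48 h; a higher number here means a weaker inhibitor, a lower number a stronger inhibitor. Compound 1 gives 31500 nM; 48600 nM (2 entries), and the spread between its repeated entries, (the several entries of compound 1 in this assay, 31500 nM; 48600 nM (2 entries)), shows how much a single number can move on retesting. Compound 2 gives 37300 nM, which lies within the scatter of compound 1. For compound 3 only a limit is reported, > 100000 nM, so it stands at the weak end of the three values, as the limit of > 100000 nM in this assay, at which 1 of the 3 values shown sits, records.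

Compound 4, `COc1cc([C@H]2C[C@@]2(CO)C(=O)NCc2ccc(C)cc2)cc(OC)c1OC`, has not yet been measured. It differs from compound 3 in one place: 4-methylbenzyl in place of phenyl on an amide-type nitrogen. Among the compounds with values here, no measured pair shows what this kind of change does on this core, so there is no step to lean on.

Given that compound 3 already sits at the limit, compound 4 is expected to remain weak, and the step of a number no higher from compound 3 to compound 4 (the limit leaves the size open) is estimated to be no larger than the usual scatter, in either direction. Compound 4 is therefore expected to give about 100000 nM, most likely between 40000 nM and 250000 nM, with a good chance that only a limit is reported again.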

Compound 4, half-maximal inhibitory concentration: 63800 nM
Estimate against measurement, compound 4: 1.6-fold (0.20 log units) above; the range from low to high includes it.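

Within the data shown here, on the amide-type nitrogen of the shared core, putting 4-methylbenzyl in place of phenyl gives, in this assay, an at least 1.5-fold lower number from compound 3 to compound 4 (0.19 log units; that floor lies within the scatter), and this is the first step at this position that can be read at all. Compound 4 gives an actual number, 63800 nM, so this change does not push the compound out of the measurable range, although that number still describes only a weak cytotoxic effect. The true size of the step stays unknown, and its floor does not pass the usual scatter, because the starting point is a limit and not a number: the limit of > 100000 nM in this assay, at which 1 of the 4 values shown sits.

The compounds shown leave open whether the step belongs to the benzyl part or to the methyl group of 4-methylbenzyl, and a plain benzyl group on the same nitrogen would separate the two. They also leave open how a longer chain such as 2-phenylethyl, or an amine or a carboxylic acid on the aromatic ring of the benzyl group, would read in this assay.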